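Adding a formyl group to compound 3

A few compounds are considered here, and "the series" means these few. Any claim that something is new, unique, unknown or untested is made for them only; others in the source may bear on it.

Measured so far, all in an ADME assay on MRC5 cells (Homo sapiens) for cytotoxicity, read by fluorescence, with a stated time of 72 h; a lower number here means a stronger inhibitor, a higher number a weaker inhibitor:
compound 1 `C[C@]1(COc2ccc(OC(F)(F)F)cc2)Cn2cc([N+](=O)[O-])nc2O1`: > 64000 nM
compound 2 `O=[N+]([O-])c1cn2c(n1)OC(COc1ccc(-c3ccc(F)cc3)nc1)C2`: > 64000 nM
compound 3 `CC1(COc2ccc(OC(F)(F)F)cc2)Cn2ccnc2O1`: > 64000 nM

Compound 3 gives > 64000 nM, and this is a limit of the assay, not a number. It has company, as the limit of > 64000 nM in this assay, at which 3 of the 3 values shown sit, shows. Compound 4 `CC1(COc2ccc(OC(F)(F)F)cc2)Cn2cc(C=O)nc2O1` is compound 3 with one change, formyl in place of hydrogen on an aromatic carbon. Going by the values given here, no measured pair shows a single change of this kind, so the forecast rests on little. A small step or none is expected in this assay, and any step should run towards a lower number, given (the limit of > 64000 nM in this assay, at which 3 of the 3 values shown sit). The estimated change is an at least 1.2-fold lower number from compound 3 to compound 4 (0.10 log units; that floor lies within the scatter). For compound 4 the expected value is 50000 nM, with an estimated range from 20000 nM to 64000 nM.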

Compound 4, half-maximal inhibitory concentration: > 64000 nM
Compound 4: a limit, no number; the forecaster's own chance of this, stated with the estimate: 65%; middle value at least 1.2-fold (0.10 log units) from the limit.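

Compound 3 and compound 4 each give a limit of the assay rather than a number, so no step can be read between them: the limit of > 64000 nM in this assay, at which 4 of the 4 values shown sit.

The compounds shown leave open whether formyl in place of hydrogen changes the result in this assay at all.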